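Oxan-4-yl to 1-methylpiperidin-4-yl: oral exposure notes

A few compounds are considered here, and "the series" means these few. Any claim that something is new, unique, unknown or untested is made for them only; others in the source may bear on it.

Measured in an ADME assay on the whole organism (Mus musculus, strain Balb/c) for pharmacokinetics, at a dose of 10 mg/kg by the oral route; on this read-out higher numbers stand for higher exposure at the dose given and lower numbers for lower exposure:
compound 1 `Cc1nc(C)n(CC(=O)N2CCN(c3sc(C(F)(F)F)nc3-c3nc4c(F)cccc4[nH]3)C[C@H]2C)n1` gives 41500 ng.h/mL
compound 2 `Cc1nc(C)n(CC(=O)N2CCN(c3sc(C(F)(F)F)nc3-c3nc4ccc(C5CCOCC5)cc4[nH]3)C[C@H]2C)n1` gives 545 ng.h/mL
compound 3 `C[C@@H]1CN(c2sc(C(F)(F)F)nc2-c2nc3ccccc3[nH]2)CCN1C(=O)Cn1cnc2cccnc21` gives 2890 ng.h/mL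

Compound 2 stands lowest of the three numbers in this assay; compound 3 lies above it beyond the scatter, and compound 1 further above still. For the measured compounds named here, no pair of these three differs in a single place, so no single step has been measured.

Compound 4 `Cc1nc(C)n(CC(=O)N2CCN(c3sc(C(F)(F)F)nc3-c3nc4ccc(C5CCN(C)CC5)cc4[nH]3)C[C@H]2C)n1` differs from compound 2 by one change: 1-methylpiperidin-4-yl in place of oxan-4-yl on an aromatic carbon. Going by the values given here, no measured compound shows what such a change does in this assay, so the expected step is none beyond the scatter, in either direction. The estimated step from compound 2 to compound 4 is a 1.1-fold lower number from compound 2 to compound 4 (0.04 log units; within the scatter). Compound 4 is therefore expected at about 500 ng.h/mL, within 100 ng.h/mL to 2500 ng.h/mL.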

Compound 4, area under the concentration-time curve: 54.6 ng.h/mL
For compound 4 the middle estimate is 9.2-fold (0.96 log units) above the measured one; measured number outside the range, below it.
By their numbers in this assay, from the lowest: compound 4; then compound 2; then compound 3; then compound 1.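

In this assay, the group on this aromatic carbon matters: 1-methylpiperidin-4-yl in place of oxan-4-yl gives a 10-fold lower number from compound 2 to compound 4 (1.00 log units; beyond the scatter) and this step lies beyond the scatter. For the compounds shown here, it is the first single-place step, and it shows that this exchange between two six-membered non-aromatic rings is enough on its own to move oral exposure. No measured property available here accounts for the step.

As far as these compounds go, whether the ring nitrogen or its methyl group carries the step stays open. How piperidin-4-yl without the methyl group, or morpholine, would compare at this position also remains unanswered.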